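From pyridin-2-yl to 3-(methylsulfonyl)phenyl on the shared core

The source may hold more compounds than are shown below. What is called first, only, known or untested is meant among the compounds shown, and "the series" means these compounds.

- compound 1 `C[C@H](Nc1ncnc2[nH]cnc12)c1nn(-c2cccnc2)c2cc(F)ccc12`: > 40000 nM (a limit)
- compound 2 `C[C@H](Nc1ncnc2[nH]cnc12)c1nn(-c2ccc(C#N)cc2)c2cc(F)ccc12`: 31500 nM
- compound 3 `C[C@H](Nc1ncnc2[nH]cnc12)c1nn(-c2ccccn2)c2cc(F)ccc12`: > 40000 nM (a limit)

In a functional assay on Bel-7402 cells (Homo sapiens) for inhibition, read by sulforhodamine B assay, with a stated time of 72 h (on this read-out lower numbers stand for stronger inhibition and higher numbers for weaker inhibition), compound 3 gives > 40000 nM, which is a limit and not a number. It sits at the limit of > 40000 nM in this assay, at which 2 of the 3 values shown sit. Compound 4 `C[C@H](Nc1ncnc2[nH]cnc12)c1nn(-c2cccc(S(C)(=O)=O)c2)c2cc(F)ccc12` differs from it as follows: 3-(methylsulfonyl)phenyl in place of pyridin-2-yl on an aromatic nitrogen. Three steps swap the group on that aromatic nitrogen: an at least 1.2-fold lower number from compound 1 to compound 2 (0.10 log units; that floor lies within the scatter), a step that the two limits leave unreadable from compound 1 to compound 3 and an at least 1.2-fold higher number from compound 2 to compound 3 (0.10 log units; that floor lies within the scatter). None of them shows a change beyond the scatter, so no clear step is expected in this assay here. The expected outcome is an at least 1.1-fold lower number from compound 3 to compound 4 (0.05 log units; that floor lies within the scatter). For compound 4 the estimated value is 35000 nM, with an expected range from 15000 nM to 80000 nM.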

Compound 4, half-maximal inhibitory concentration: 20000 nM
For compound 4 the middle estimate is 1.8-fold (0.24 log units) above the measured one, and the stated range covers the measured number.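

In this assay, going by these compounds alone, the swap to 3-(methylsulfonyl)phenyl gives the first step on this aromatic nitrogen that joins two real numbers: a 1.6-fold lower number from compound 2 to compound 4 (0.20 log units; within the scatter). Against the other two compounds it gives an at least 2.0-fold lower number from compound 3 to compound 4 (0.30 log units; that floor lies within the scatter) and an at least 2.0-fold lower number from compound 1 to compound 4 (0.30 log units; that floor lies within the scatter), so no swap at this position yet shows a change beyond the scatter. Compound 1 and compound 3 remain limits and not numbers: the limit of > 40000 nM in this assay, at which 2 of the 4 values shown sit.

On these data alone, whether an amine or a carboxylic acid on the phenyl ring would move the number beyond the scatter stays open.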